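From aryl to arylamino on the shared core

The compounds below may be only part of what the source reports. "The series", "measured", "known", "first", "only" and "open" are said of these compounds alone.

In a functional assay on HeLa cells (Homo sapiens) for antiproliferative activity, read by MTT assay, with a stated time of 72 h (a lower number here means a stronger inhibitor, a higher number a weaker inhibitor), compound 1 `COc1cc(C(=O)c2sc3ccccc3c2-c2ccc(C)cc2)cc(OC)c1OC` gives 3700 nM and compound 2 `COc1ccc(-c2c(C(=O)c3cc(OC)c(OC)c(OC)c3)sc3ccccc23)cc1` gives 4200 nM while compound 3 `COc1ccc(-c2c(C(=O)c3cc(OC)c(OC)c(OC)c3)sc3ccccc23)c(OC)c1` gives 3900 nM so compound 3 stands level with the other two, all three lying within the usual scatter of one another.

Compound 4 `COc1ccc(Nc2c(C(=O)c3cc(OC)c(OC)c(OC)c3)sc3ccccc23)cc1` is reached from compound 3 by the change (4-methoxyphenyl)amino in place of 2,4-dimethoxyphenyl on an aromatic carbon with (4-methoxyphenyl)amino in place of 2,4-dimethoxyphenyl on an aromatic carbon.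

The measured steps vary only the substituents on the aryl group: a 1.1-fold higher number from compound 1 to compound 2 (0.06 log units; within the scatter) and a 1.1-fold higher number from compound 1 to compound 3 (0.02 log units; within the scatter) and a 1.1-fold lower number from compound 2 to compound 3 (0.03 log units; within the scatter) are all small. None of them brings in an amino group, so the series gives no measured size for this change. A step beyond the scatter remains possible in either direction, and the slight lean to a lower number in this assay is a judgement without measured support. The expected step is a 2.0-fold lower number from compound 3 to compound 4 (0.29 log units; within the scatter) as a loose estimate only.

The estimate for compound 4 is 2000 nM with an expected range of 200 nM to 10000 nM in this assay.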

Compound 4, half-maximal inhibitory concentration: 7700 nM
Compound 4: the middle estimate sits 3.9-fold (0.59 log units) below what was measured, within the range that was stated.
By their numbers in this assay, from the lowest: compounds 1, 3, 2 and 4 (each within the scatter of the next, the first and the last beyond it).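

In this assay, among the compounds shown here, the position on the five-membered aromatic ring now carries an amino link for the first time, and against the closest aryl analogue the result is a 1.8-fold higher number from compound 2 to compound 4 (0.26 log units; within the scatter), with a 2.0-fold higher number from compound 3 to compound 4 (0.30 log units; within the scatter) also staying level. Only a 2.1-fold higher number from compound 1 to compound 4 (0.32 log units; beyond the scatter) clears the scatter, and that step is modest. The entering hydrogen-bond donor therefore comes with no lower number in any of the three comparisons, and nothing available accounts for the size of these steps.

Still open, on these data alone, is how a plain unsubstituted amino group, a methylamino link or an ether oxygen link would read at this position. Also open, as far as these compounds go, is whether the 2,4-dimethoxyphenyl or 4-methylphenyl group would give a different number when carried on the amino link.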